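The source may hold more compounds than are shown below. What is called first, only, known or untested is meant among the compounds shown, and "the series" means these compounds.

Compound 1 `CN1C(=S)[C@@H](NC(=O)c2nc(Cc3ccccc3)n(CCCCCC#N)n2)COc2ccccc21` gives 3830 nM in a functional assay on HT-29 cells (Homo sapiens) for inhibition, read by luminescence and CellTiter-Glo, with a stated time of 24 h (on this read-out lower numbers stand for an effect already at smaller amounts and higher numbers for an effect only at larger amounts of compound), the lowest of the two numbers recorded there. Compound 2 `CN1C(=S)[C@@H](NC(=O)c2nc(Cc3ccccc3)n(CC3CCOCC3)n2)COc2ccccc21` gives 6310 nM in this assay, and the step of a 1.6-fold higher number from compound 1 to compound 2 (0.22 log units; within the scatter) stays within the scatter. Compound 3 `CN1C(=S)[C@@H](NC(=O)c2nc(Cc3ccccc3)n(C3CCN(C(=O)OC(C)(C)C)CC3)n2)COc2ccccc21` gives only a limit in this assay, > 10000 nM, the point the limit of > 10000 nM in this assay, at which 1 of the 3 values shown sits, where one of three values sits. Compound 4 `CN1C(=S)[C@@H](NC(=O)c2nc(Cc3ccccc3)n(Cc3ccccc3)n2)COc2ccccc21` differs from compound 1 in one place: phenyl in place of 4-cyanobutyl on a saturated chain carbon bound to an aromatic nitrogen. For the measured compounds named here, the only measured step at this position, that from compound 1 to compound 2, was within the scatter, so no step beyond the scatter is expected here either. Compound 4 is therefore estimated at 3500 nM in this assay, ranging from 1200 nM to 10000 nM, an expected step of a 1.1-fold lower number from compound 1 to compound 4 (0.04 log units; within the scatter).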

Compound 4, half-maximal effective concentration: 414 nM
Estimate against measurement, compound 4: 8.5-fold (0.93 log units) above; the whole stated range lies above it.
By their numbers in this assay, from the lowest: compound 4; then compounds 1 and 2 (each within the scatter of the next). At a limit, above all of these: compound 3.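

The position is not indifferent to what it carries: 4-cyanobutyl and oxan-4-yl stayed within the scatter of each other, but in this assay phenyl gives a 9.3-fold lower number from compound 1 to compound 4 (0.97 log units; beyond the scatter) and a 15-fold lower number from compound 2 to compound 4 (1.18 log units; beyond the scatter). Among these three compounds, compound 4, the one with an aromatic ring at this place, stands apart. Nothing given here accounts for this gain.

From the compounds shown here alone, whether it needs an aromatic ring or any ring of carbon stays open. Cyclohexyl, pyridinyl or a methoxy-bearing phenyl at this place would separate these readings.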